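This account rests on a few compounds, and the source may have more. Where it says the series, first, only, none or still open, it means among the compounds named here.

Measured in a functional assay on MDA-MB-231 cells (Homo sapiens) for antiproliferative activity, read by sulforhodamine B assay, with a stated time of 48 h; on this read-out higher numbers stand for weaker inhibition and lower numbers for stronger inhibition:

compound 1, `COc1ccc2nc(-c3ccc(N/C=C\C(=O)c4ccc(OC)c([N+](=O)[O-])c4)cc3)sc2c1`: 17600 nM
compound 2, `COc1ccc(C(=O)/C=C\Nc2ccc(-c3nc4cc(OC)c(OC)c(OC)c4s3)cc2)cc1[N+](=O)[O-]`: 17100 nM
compound 3, `COc1ccc2nc(-c3ccc(N/C=C\C(=O)c4ccc(OC)c(F)c4)cc3)sc2c1`: 1100 nM

Compound 1 and compound 2 carry the same substituted aryl ketone but differ in the core; the difference between the two cores is not broken down here. Their values in this assay lie within the usual scatter of each other.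

Compound 3 differs from compound 1 by fluoro in place of nitro on an aromatic carbon. This single change gave a 16-fold lower number from compound 1 to compound 3 (1.20 log units; beyond the scatter).

Compound 4, `COc1ccc(C(=O)/C=C\Nc2ccc(-c3nc4cc(OC)c(OC)c(OC)c4s3)cc2)cc1F`, is not yet measured. It differs from compound 2 by fluoro in place of nitro on an aromatic carbon. The place lines for the two changes read the same word for word, so this is the same change, now on the core of compound 2. For the measured compounds named here, the only measured instance of it is a 16-fold lower number from compound 1 to compound 3 (1.20 log units; beyond the scatter); with compound 2 giving 17100 nM as the starting point, a step of similar size is expected, though it rests on one pair only. The expected step is a 14-fold lower number from compound 2 to compound 4 (1.15 log units; beyond the scatter). Compound 4 is therefore estimated at 1200 nM, with a likely range from 400 nM to 4000 nM.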

Compound 4, half-maximal inhibitory concentration: 16500 nM
Beside the measured number, compound 4's estimate is 14-fold (1.14 log units) below it; measured number outside the range, above it.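

On the core of compound 2, the change gave a 1.0-fold lower number from compound 2 to compound 4 (0.02 log units; within the scatter) in this assay. Fluoro in place of nitro therefore does not carry over in size from the core of compound 1 to the core of compound 2, and the two steps differ: the same change on two cores in this assay, a 16-fold lower number (1.20 log units; beyond the scatter) from compound 1 to compound 3 and a 1.0-fold lower number (0.02 log units; within the scatter) from compound 2 to compound 4, 15-fold (1.19 log units) apart, beyond the scatter of two such steps. This shows that in these two pairs the size of the step depends on the core, so a step read on one core is a poor guide to the other; with one pair per core, it does not show which part of the core difference matters, or how the change would behave on any further core.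

The compounds shown leave open whether another group in place of nitro, such as chloro, an amine or a nitrile, would also separate the two cores. Also open, on these data alone, is how the step would read on cores lying between these two, which would break the core difference into parts.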